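From 4-propylphenyl to 3-chlorophenyl on the amine nitrogen

A few compounds are considered here, and "the series" means these few. Any claim that something is new, unique, unknown or untested is made for them only; others in the source may bear on it.

Compound 1 `O=C1C(N2CCCC2)=CC(=O)c2c1nc1n2[C@H]2OC[C@@H](O)[C@H]2OC1`: > 16000 nM
Compound 2 `CCCc1ccc(NC2=CC(=O)c3c(nc4n3[C@H]3OC[C@@H](O)[C@H]3OC4)C2=O)cc1`: > 4000 nM

In a functional assay on ECa-109 cells for inhibition, with ECa-109 cell line (Homo sapiens) as the target, read by sulforhodamine B assay (a higher number here means a weaker inhibitor, a lower number a stronger inhibitor), compound 2 gives > 4000 nM, which is a limit of the assay and not a number. Compound 1 also gives only a limit, > 16000 nM. Compound 3 `O=C1C(Nc2cccc(Cl)c2)=CC(=O)c2c1nc1n2[C@H]2OC[C@@H](O)[C@H]2OC1` carries 3-chlorophenyl in place of 4-propylphenyl on an amine nitrogen. Going by the values given here, no measured step shows what this swap does. The expectation therefore rests on compound 2 and its limit, > 4000 nM. Only a small shift towards a stronger inhibitor is expected, an estimated at least 1.3-fold lower number from compound 2 to compound 3 (0.12 log units; that floor lies within the scatter). The estimate for compound 3 is 3000 nM, with an expected range of 700 nM to 12000 nM.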

Compound 3, half-maximal inhibitory concentration: 3080 nM
Beside the measured number, compound 3's estimate is 1.0-fold (0.01 log units) below it; measured number inside the range.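

In this assay, compound 3 gives a true number, whereas compound 1 and compound 2 each gave only a limit. Placing (3-chlorophenyl)amino in place of pyrrolidin-1-yl on the double-bonded ring carbon gives an at least 5.1-fold lower number from compound 1 to compound 3 (0.71 log units; beyond the scatter), so this position tolerates a change that clearly lowers the number. The swap of 4-propylphenyl for 3-chlorophenyl gives an at least 1.2-fold lower number from compound 2 to compound 3 (0.11 log units; that floor lies within the scatter), which does not by itself establish a real gain.

Going by these compounds, the true size of that swap remains open. Also open, on these data alone, is what a methoxy group or fluorine on the phenyl ring, or a benzyl group on the amine nitrogen, would do.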